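This account rests on a few compounds, and the source may have more. Where it says the series, first, only, none or still open, it means among the compounds named here.

Compound 1 `CC(=O)c1c(C)nc2c(OCc3ccccc3)cccn12`: 57%
Compound 2 `Cc1nc2c(OCc3ccccc3)cccn2c1CCC#N`: 40%
Compound 3 `Cc1nc2c(OCc3ccccc3)cccn2c1CO`: 99%

In a functional assay on the whole organism with Rattus norvegicus as the target, with a stated time of 4 h, at a dose of 40 mg/kg by the intraperitoneal route (on this read-out higher numbers stand for more inhibition at the one dose given (going by the name of the read-out) and lower numbers for less inhibition), compound 3 stands highest of the three, a number a number 42 percentage points higher from compound 1 to compound 3 (beyond the scatter) and a number 59 percentage points higher from compound 2 to compound 3 (beyond the scatter). Compound 4 `COCc1c(C)nc2c(OCc3ccccc3)cccn12` is not yet measured; it differs from compound 3 in one place: methyl in place of hydrogen on an oxygen on a saturated carbon.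

Within the data shown here, two measured steps bear on this position. The group on that aromatic carbon moved from acetyl to hydroxymethyl with a number 42 percentage points higher from compound 1 to compound 3 (beyond the scatter), and from cyanoethyl to hydroxymethyl with a number 59 percentage points higher from compound 2 to compound 3 (beyond the scatter). In both the hydroxymethyl compound came out highest, so the hydroxy group appears to carry much of the weight, though with three compounds no wider pattern can be claimed. Capping that hydroxy with methyl removes the only hydrogen-bond donor among these groups. She therefore expects compound 4 to fall from compound 3, a step of a number 29 percentage points lower from compound 3 to compound 4 (beyond the scatter), beyond the scatter but likely less steep than the drop to compound 2, because the methoxymethyl keeps the short oxygen-bearing chain of compound 3 which gave 99%. Compound 4 is estimated at 70%, within 40% to 95%.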

Compound 4, a percentage reported as inhibition, in the whole organism at one dose (the size of the read-out at that dose, not a potency): 99%
Estimate against measurement, compound 4: 29 percentage points below, outside the stated range (above it).
By their numbers in this assay, from the lowest: compound 2; then compound 1; then compounds 3 and 4 (each within the scatter of the next).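

In this assay, capping the hydroxy of the hydroxymethyl group with methyl gives no measurable shift (no change at the digits printed from compound 3 to compound 4 (within the scatter)), so at this position the hydrogen on that oxygen is not required for the response at this dose. The methoxymethyl group also keeps the full lead of the hydroxymethyl group over the other two groups (a number 42 percentage points higher from compound 1 to compound 4 (beyond the scatter); a number 59 percentage points higher from compound 2 to compound 4 (beyond the scatter)), which places the advantage with the short oxygen-bearing chain rather than with the free hydroxy. No measurement offered here explains why the two groups match.

Going by these compounds, it stays open whether an amine or a carboxylic acid on that aromatic carbon, or a longer ether such as ethoxymethyl, would hold the response. On these data alone, with only one dose, it also stays open whether compound 3 and compound 4 would separate at a lower dose.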